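Replacing 4-hydroxyphenyl in compound 3

The source may hold more compounds than are shown below. What is called first, only, known or untested is meant among the compounds shown, and "the series" means these compounds.

Within the data shown here, in a functional assay on MCF7 cells (Homo sapiens) (a lower number here means a stronger inhibitor of growth, a higher number a weaker inhibitor of growth), compound 3 (`O=S(=O)(/C=C/c1ccc(O)cc1)Cc1ccc(Nc2ncnc3ccc(Br)cc23)cc1`) gives 32000 nM, the middle of the three numbers so far. Compound 2 (`O=S(=O)(/C=C/c1ccc(Cl)c(Cl)c1)Cc1ccc(Nc2ncnc3ccc(Br)cc23)cc1`) lies lower at 14000 nM, and compound 1 (`O=S(=O)(/C=C/c1ccc(C(F)(F)F)cc1F)Cc1ccc(Nc2ncnc3ccccc23)cc1`) lies higher at 100000 nM.

Compound 4 (`O=S(=O)(/C=C/c1ccc(C(F)(F)F)cc1F)Cc1ccc(Nc2ncnc3ccc(Br)cc23)cc1`) carries 2-fluoro-4-(trifluoromethyl)phenyl in place of 4-hydroxyphenyl on a double-bonded chain carbon bound to a double-bonded chain carbon.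

Among the measured compounds shown here, one measured step bears directly on this place: a 2.3-fold higher number from compound 2 to compound 3 (0.36 log units; beyond the scatter). It is modest but beyond the scatter, and it leaves the 4-hydroxyphenyl compound with the higher number. Compound 1 also carries 2-fluoro-4-(trifluoromethyl)phenyl, but on a core other than that of compound 3, and it has the highest number of the three. A large drop is therefore not assumed, and a single step supports no firm trend.

The expected step is a 2.1-fold lower number from compound 3 to compound 4 (0.33 log units; beyond the scatter), modest and towards a lower number. For compound 4 the estimate is 15000 nM, with an expected range of 5000 nM to 45000 nM.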

Compound 4, concentration for 50% growth inhibition: 32000 nM
For compound 4 the middle estimate is 2.1-fold (0.33 log units) below the measured one; the range from low to high includes it.
By their numbers in this assay, from the lowest: compound 2; then compounds 3 and 4 (each within the scatter of the next); then compound 1.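

In this assay, the exchange at this position gives no change at the digits printed from compound 3 to compound 4 (within the scatter), so the 4-hydroxyphenyl and 2-fluoro-4-(trifluoromethyl)phenyl groups cannot be told apart here, even though one carries a hydrogen-bond donor and the other carries none. On the shared bromo core, 3,4-dichlorophenyl now stands apart from both groups: the step to the 4-hydroxyphenyl compound is a 2.3-fold higher number from compound 2 to compound 3 (0.36 log units; beyond the scatter), and the step to the fluorinated compound is a 2.3-fold higher number from compound 2 to compound 4 (0.36 log units; beyond the scatter). With 2-fluoro-4-(trifluoromethyl)phenyl held constant, bromo in place of hydrogen on an aromatic carbon gives a 3.1-fold lower number from compound 1 to compound 4 (0.49 log units; beyond the scatter), a modest step at a second place in the molecule.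

No measurement shown accounts for any of these numbers.

On these data alone, it remains open whether a phenyl ring carrying an amine or a carboxylic acid would fall with compound 2 or with compounds 3 and 4, and whether the bromo step holds with other groups at this position.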